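Sulfonamide nitrogen substitution in the thiourea series

The source may report more compounds than this note shows. Statements on the series, on what has been measured and on what is new or still open speak of the compounds shown alone.

Compound 1 `NS(=O)(=O)c1ccc(N/C(S)=N\c2ccnc3cc(C(F)(F)F)ccc23)cc1` gives 36600 nM in a functional assay on AS49-RAW cells (Homo sapiens) for antiproliferative activity, read by sulforhodamine B assay, with a stated time of 48 h (a higher number here means a weaker inhibitor, a lower number a stronger inhibitor), the second highest of the three numbers recorded; compound 3 `Cc1noc(NS(=O)(=O)c2ccc(N/C(S)=N\c3ccnc4cc(C(F)(F)F)ccc34)cc2)c1C` gives 34000 nM and compound 2 `Cc1cc(NS(=O)(=O)c2ccc(N/C(S)=N\c3ccnc4cc(C(F)(F)F)ccc34)cc2)on1` gives 60200 nM. Compound 4 `O=S(=O)(Nc1ccccn1)c1ccc(N/C(S)=N\c2ccnc3cc(C(F)(F)F)ccc23)cc1` differs from compound 1 by pyridin-2-yl in place of hydrogen on a sulfonamide nitrogen. Among the compounds with values here, the steps that bear on this change replace the same hydrogen with an aromatic heterocycle: a 1.6-fold higher number from compound 1 to compound 2 (0.22 log units; within the scatter) and a 1.1-fold lower number from compound 1 to compound 3 (0.03 log units; within the scatter), both within the scatter. Placing the pyridin-2-yl group on the sulfonamide nitrogen is therefore expected to move the number little in this assay, with no step beyond the scatter in either direction. For compound 4 the expected step is a 1.1-fold higher number from compound 1 to compound 4 (0.04 log units; within the scatter). The estimate for compound 4 is 40000 nM, with a range from 15000 nM to 100000 nM.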

Compound 4, half-maximal inhibitory concentration: 33500 nM
Compound 4: the middle estimate sits 1.2-fold (0.08 log units) above what was measured; the measured number falls inside the stated range.
By their numbers in this assay, from the lowest: compounds 4, 3, 1 and 2 (each within the scatter of the next).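

With pyridin-2-yl on the sulfonamide nitrogen, the number in this assay stays within the scatter of the unsubstituted compound (a 1.1-fold lower number from compound 1 to compound 4 (0.04 log units; within the scatter)). It also stays within the scatter of both 1,2-oxazol-5-yl compounds (a 1.0-fold lower number from compound 3 to compound 4 (0.01 log units; within the scatter)) and (a 1.8-fold lower number from compound 2 to compound 4 (0.25 log units; within the scatter)). This position therefore accepts a six-membered aromatic ring with one hetero atom as well, with no step beyond the scatter. No measurement on hand accounts for this flat response.

Still open, from the compounds shown here alone, is whether a non-aromatic group on this nitrogen, such as a longer alkyl chain or a chain ending in a carboxylic acid, would give a step beyond the scatter.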